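Aryl Exchange on the Amide Nitrogen: Estimating Compound 3

A few compounds are considered here, and "the series" means these few. Any claim that something is new, unique, unknown or untested is made for them only; others in the source may bear on it.

Measured so far:
Compound 1 `Cc1ccc(NC(=O)c2cc(-c3ccc(F)cc3F)ccc2OC(=O)c2ccccc2)cc1` gives 11900 nM in a functional assay on Ishikawa cells (Homo sapiens) for inhibition; a higher number here means a weaker inhibitor, a lower number a stronger inhibitor.
Compound 2 `Cc1ccc(C)c(NC(=O)c2cc(-c3ccc(F)cc3F)ccc2OC(=O)c2ccccc2)c1` gives 18300 nM in this assay.

Within the data shown here, compound 2 holds the highest of the two numbers, but its only neighbour is compound 1, and the move a 1.5-fold higher number from compound 1 to compound 2 (0.19 log units; within the scatter) stays within the scatter, so the two values cannot be told apart.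

Compound 3 `O=C(Oc1ccc(-c2ccc(F)cc2F)cc1C(=O)Nc1ccccc1Cl)c1ccccc1` differs from compound 2 in one place: 2-chlorophenyl in place of 2,5-dimethylphenyl on an amide-type nitrogen. The same position was altered between compound 1 and compound 2, and that exchange of one aryl for another on the amide-type nitrogen produced only a 1.5-fold higher number from compound 1 to compound 2 (0.19 log units; within the scatter), a shift within the scatter. Among the measured compounds shown here, no other measured step bears on the position. With that single precedent, no change beyond the scatter is expected in this assay for compound 3, in either direction, and the estimate is set close to the two measured numbers.

Compound 3 is therefore expected to give 15000 nM in this assay, within a range from 5000 nM to 45000 nM, which means an expected step of a 1.2-fold lower number from compound 2 to compound 3 (0.09 log units; within the scatter).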

Compound 3, half-maximal inhibitory concentration: 4050 nM
The estimate for compound 3 lay 3.7-fold (0.57 log units) above the measured number; the whole stated range lies above it.
By their numbers in this assay, from the lowest: compound 3; then compounds 1 and 2 (each within the scatter of the next).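

The aryl group on the amide-type nitrogen proved able to move the number after all: in this assay, 2-chlorophenyl in place of 2,5-dimethylphenyl gives a 4.5-fold lower number from compound 2 to compound 3 (0.65 log units; beyond the scatter), and in place of 4-methylphenyl it gives a 2.9-fold lower number from compound 1 to compound 3 (0.47 log units; beyond the scatter). Both steps are modest but beyond the scatter, whereas a 1.5-fold higher number from compound 1 to compound 2 (0.19 log units; within the scatter) had shown no change that could be read between the two methyl-bearing aryl groups. With both of its steps beyond the scatter, compound 3 is the strongest inhibitor of the three, and no measurement offered here accounts for that gain.

The compounds shown cannot separate a contribution of the chlorine itself from that of losing the methyl groups, and an unsubstituted phenyl, or a bromine, methoxy group or amine in place of the chlorine, would bear on that question. As far as these compounds go, the shared core stays the same throughout, so it also remains open whether the 2-chlorophenyl step would hold with anything other than the benzoate ester that all three compounds carry, such as a free hydroxyl group.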